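The compounds below may be only part of what the source reports. "The series", "measured", "known", "first", "only" and "open" are said of these compounds alone.

Three compounds share one core and differ only in the ester group attached to it. Compound 1 `CC(C)OC(=O)OCOC(=O)C1=C(S[C@@H]2CN[C@H](C(=O)Nc3cccc(C(=O)O)c3)C2)[C@H](C)[C@@H]2[C@@H]([C@@H](C)O)C(=O)N12` carries an isopropoxy group on that carbonyl carbon, compound 2 `CCOC(=O)OCOC(=O)C1=C(S[C@@H]2CN[C@H](C(=O)Nc3cccc(C(=O)O)c3)C2)[C@H](C)[C@@H]2[C@@H]([C@@H](C)O)C(=O)N12` an ethoxy group, and compound 3 `CCC(CC)C(=O)OCOC(=O)C1=C(S[C@@H]2CN[C@H](C(=O)Nc3cccc(C(=O)O)c3)C2)[C@H](C)[C@@H]2[C@@H]([C@@H](C)O)C(=O)N12` a pentan-3-yl group. In an ADME assay for metabolic stability, read by LC-MS, with a stated time of 3 h, at pH 6.5, tested at 50 uM (on this read-out lower numbers stand for a less stable compound and higher numbers for a more stable compound), compound 1 reports > 95%, which is a limit of the measurement rather than a number. In this assay compound 2 likewise reports the limit > 95%. Compound 3 also reports the limit > 95%. Because all three values sit at the limit of > 95% in this assay, at which 3 of the 3 values shown sit, the steps a step that the two limits leave unreadable from compound 1 to compound 2, a step that the two limits leave unreadable from compound 1 to compound 3 and a step that the two limits leave unreadable from compound 2 to compound 3 cannot be sized, so compound 3 stands level with the others as far as the measurement can tell. Compound 4 `CC(C)OC(=O)C1=C(S[C@@H]2CN[C@H](C(=O)Nc3cccc(C(=O)O)c3)C2)[C@H](C)[C@@H]2[C@@H]([C@@H](C)O)C(=O)N12` differs from compound 3 by isopropyl in place of (((pentan-3-yl)carbonyl)oxy)methyl on an oxygen next to a carbonyl group. For the measured compounds named here, no measured step covers this change, and the three measured steps are all unreadable. Compound 4 is therefore expected to remain near the limit, at an estimated 90% with a range from 70% to 99%, which corresponds to an expected step of a number at least 5 percentage points lower from compound 3 to compound 4 (that floor lies within the scatter).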

Compound 4, percent of the compound remaining: > 95%
Compound 4: no number, only a limit; the forecaster's own chance of this, stated with the estimate: 55%; at least 5 percentage points between middle value and limit.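

In this assay compound 4 gives > 95%, a limit rather than a number, so its steps from compound 1, compound 2 and compound 3 cannot be read: the limit of > 95% in this assay, at which 4 of the 4 values shown sit. The compounds shown leave open whether these four differ at all in the percent of compound remaining.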